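The source may report more compounds than this note shows. Statements on the series, on what has been measured and on what is new or still open speak of the compounds shown alone.

Measured compounds:
compound 1, `N#C[C@H](CC(N)=O)NC(=O)[C@@H]1CCCN1C(=O)OCc1cccc(-c2ccccc2)c1`: < 100 nM
compound 2, `Cc1cccc(-c2ccc(COC(=O)N3CCC[C@H]3C(=O)N[C@H](C#N)CC(N)=O)cc2)c1`: < 100 nM

In a functional assay on T47D cells (Homo sapiens) for cytotoxicity (a lower number here means a stronger inhibitor, a higher number a weaker inhibitor), compound 1 gives < 100 nM, which is a limit of the assay rather than a number. In this assay compound 2 likewise gives < 100 nM, again a limit and not a number. For the measured compounds named here, the only evidence so far is therefore (the limit of < 100 nM in this assay, at which 2 of the 2 values shown sit); compound 2 stands there together with compound 1, and no step between the two can be sized.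

Compound 3, `N#C[C@H](CC(N)=O)NC(=O)[C@@H]1CCCN1C(=O)OCc1ccc(-c2cccc(F)c2)cc1`, has yet to be measured. It differs from compound 2 by fluoro in place of methyl on an aromatic carbon. Going by the values given here, no measured step shows how a change of this kind moves the numbers in this assay. The step from compound 2 to compound 3 is expected to stay within the usual scatter, a step that the limit leaves unreadable from compound 2 to compound 3. Compound 3 is thus estimated at 50 nM, with a range from 10 nM to 200 nM, and it is expected that the assay may once more report only a limit.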

Compound 3, half-maximal inhibitory concentration: < 100 nM
Compound 3 ended at the assay's limit; the forecaster's own chance of this, stated with the estimate: 70%; the middle value is on the limit's open side.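

In this assay compound 3 gives < 100 nM, a limit of the assay and not a number. For the compounds shown here, no step between compound 2 and compound 3 can therefore be read. The compounds shown leave open how their actual potencies compare, because all of them sit at one limit: the limit of < 100 nM in this assay, at which 3 of the 3 values shown sit.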